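Methylphenyl position in a Substance-P receptor binding series

A few compounds are considered here, and "the series" means these few. Any claim that something is new, unique, unknown or untested is made for them only; others in the source may bear on it.

Measured so far:
compound 1, `CC(=O)N1CC[C@@H](C(=O)N(C)Cc2cc(C(F)(F)F)cc(C(F)(F)F)c2)[C@H](c2ccccc2)C1`: 2.6 nM
compound 2, `CC(=O)N1CCC(C(=O)N2CC[C@H](C(=O)N(C)Cc3cc(C(F)(F)F)cc(C(F)(F)F)c3)[C@@H](c3cccc(C)c3)C2)CC1`: 0.14 nM

In an assay on IM-9 cells for displacement of a labelled ligand from Substance-P receptor (Homo sapiens), read by scintillation counting, with a stated time of 30 min (on this read-out lower numbers stand for stronger inhibition and higher numbers for weaker inhibition), compound 2 has the lower of the two numbers, and compound 1 stands higher by a gap beyond the scatter. Compound 3, `CC(=O)N1CCC(C(=O)N2CC[C@H](C(=O)N(C)Cc3cc(C(F)(F)F)cc(C(F)(F)F)c3)[C@@H](c3ccccc3C)C2)CC1`, differs from compound 2 by 2-methylphenyl in place of 3-methylphenyl on a saturated ring carbon. Going by the values given here, no measured pair shows this change, so the step has no precedent here. Compound 3 is expected to give a higher number than compound 2, with an 11-fold higher number from compound 2 to compound 3 (1.03 log units; beyond the scatter), a step beyond the scatter. The estimate for compound 3 in this assay is 1.5 nM, with a range from 0.3 nM to 10 nM.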

Compound 3, half-maximal inhibitory concentration: 0.032 nM
Estimate against measurement, compound 3: 47-fold (1.67 log units) above; the whole stated range lies above it.
By their numbers in this assay, from the lowest: compound 3; then compound 2; then compound 1.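

In this assay the place of the methyl on this phenyl group matters: 2-methylphenyl in place of 3-methylphenyl gives a 4.4-fold lower number from compound 2 to compound 3 (0.64 log units; beyond the scatter) with the heavy-atom count, donors, acceptors and charge unchanged. This single pair shows that the shift alone carries the number beyond the scatter. No measurement at hand accounts for the step.

Open, from the compounds shown here alone, is how 4-methylphenyl, a methoxyphenyl or a chlorophenyl group would compare on this saturated ring carbon. Also open, going by these compounds, is whether the step holds with an acetyl group in place of the (1-acetylpiperidin-4-yl)carbonyl group.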